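Methylsulfonyl for the ester-bearing acyl group on the ring nitrogen

The compounds below may be only part of what the source reports. "The series", "measured", "known", "first", "only" and "open" are said of these compounds alone.

This account concerns four compounds built on one shared core. In a functional assay on HCC1806 cells (Homo sapiens) for inhibition, read by sulforhodamine B assay, tested at 10 uM (on this read-out lower numbers stand for less inhibition and higher numbers for more inhibition at the one concentration tested (going by the name of the read-out)), compound 1 `CN(C)c1ccc(C2CC(c3ccc(-n4cncn4)cc3)=NN2)cc1` gives 6.8%, compound 2 `CN(C)c1ccc(C2CC(c3ccc(-n4ccnc4)cc3)=NN2)cc1` gives -20.9% and compound 3 `COC(=O)CC(=O)N1N=C(c2ccc(N3CCN(C)CC3)cc2)CC1c1ccc(N(C)C)cc1` gives -8.3%. Among these three numbers compound 3 stands second highest: it lies above compound 2 and below compound 1, and both of those gaps are beyond the scatter. Among the measured compounds shown here, the only step measured between two compounds differing in one place is a number 27.7 percentage points lower from compound 1 to compound 2 (beyond the scatter), which concerns the exchange on an aromatic carbon and not the ring nitrogen.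

Compound 4 `CN1CCN(c2ccc(C3=NN(S(C)(=O)=O)C(c4ccc(N(C)C)cc4)C3)cc2)CC1` differs from compound 3 by methylsulfonyl in place of ((methoxycarbonyl)methyl)carbonyl on an amine nitrogen in a ring. For the measured compounds named here, no measured pair speaks to an exchange at this place, so the step from compound 1 to compound 2 gives no direct guidance, and all three measured numbers sit close to zero in this assay. The expectation is therefore for no step beyond the scatter, with a number 3.3 percentage points higher from compound 3 to compound 4 (within the scatter) from compound 3 to compound 4. Compound 4 is estimated to give -5% in this assay, within a range from -30% to 20%.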

Compound 4, a percentage reported as inhibition, at one concentration (the size of the read-out at that concentration, not a potency): -18.5%
Estimate against measurement, compound 4: 13.5 percentage points above, within the range that was stated.
By their numbers in this assay, from the lowest: compounds 2 and 4 (each within the scatter of the next); then compound 3; then compound 1.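

In this assay, among the compounds shown here, methylsulfonyl in place of ((methoxycarbonyl)methyl)carbonyl on the amine nitrogen in a ring gives a number 10.2 percentage points lower from compound 3 to compound 4 (beyond the scatter), which is the first sign that an exchange at this place can move the read-out, though only modestly. The exchange replaces a group of 7 heavy atoms with one of 4, yet it brings no gain in inhibition: compound 3 gives -8.3% and compound 4 gives -18.5%, both numbers below zero. Nothing available bears on what lies behind this step, so the difference stands as an observation only.

The compounds shown leave open how an acetyl group, a carboxylic acid in place of the methyl ester, or a longer chain on this ring nitrogen would read in this assay. Going by these compounds, it also remains open whether the same exchange would shift the number by a similar amount on a compound carrying the 1H-1,2,4-triazol-1-yl group of compound 1.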